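The source may hold more compounds than are shown below. What is called first, only, known or untested is meant among the compounds shown, and "the series" means these compounds.

Measured so far in a functional assay on CLL cells (Homo sapiens) for cytotoxicity, read by MTT assay, with a stated time of 48 h; a higher number here means that more compound is needed for the effect, a lower number that less compound is needed:
compound 1, `C=C(CC)C(=O)c1ccc(OCC(=O)Nc2cccc(C(=O)O)c2)c(Cl)c1Cl` — 20600 nM
compound 2, `C=C(CC)C(=O)c1ccc(OCC(=O)NCO[N+](=O)[O-])c(Cl)c1Cl` — 4100 nM
compound 3, `C=C(CC)C(=O)c1ccc(OCC(=O)Nc2ccc(CC(=O)O)cc2)c(Cl)c1Cl` — 3200 nM

Compound 1 stands highest of the three: the change to compound 2 gave a 5.0-fold lower number from compound 1 to compound 2 (0.70 log units; beyond the scatter), and compound 3 lies lower still. Compound 4, `C=C(CC)C(=O)c1ccc(OCC(=O)Nc2ccc(C(N)=O)cc2)c(Cl)c1Cl`, has not yet been measured. It differs from compound 1 in one place: 4-carbamoylphenyl in place of 3-carboxyphenyl on an amide-type nitrogen. Among the compounds with values here, the only measured step that speaks to this is a 5.0-fold lower number from compound 1 to compound 2 (0.70 log units; beyond the scatter), where the same 3-carboxyphenyl group was replaced on the same amide-type nitrogen; compound 3, which also carries a different group there, shows a lower number too. Within the data shown here, both point the same way, but they are only two examples. Compound 4 is therefore expected to give 6000 nM (range 2000 nM to 20000 nM), an expected step of a 3.4-fold lower number from compound 1 to compound 4 (0.54 log units; beyond the scatter).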

Compound 4, half-maximal effective concentration: 3700 nM
Estimate against measurement, compound 4: 1.6-fold (0.21 log units) above; the measured number falls inside the stated range.
By their numbers in this assay, from the lowest: compounds 3, 4 and 2 (each within the scatter of the next); then compound 1.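

Replacing 3-carboxyphenyl with 4-carbamoylphenyl on the amide-type nitrogen in this assay also lowers the number (a 5.6-fold lower number from compound 1 to compound 4 (0.75 log units; beyond the scatter)), so all three replacements shown for that group do so. Compound 4 cannot be told apart from the other two, either from its carbamoyl in place of carboxymethyl on an aromatic carbon (a 1.2-fold higher number from compound 3 to compound 4 (0.06 log units; within the scatter)) or from its 4-carbamoylphenyl in place of (nitrooxy)methyl (a 1.1-fold lower number from compound 2 to compound 4 (0.04 log units; within the scatter)). No measurement shown explains these steps. Compound 4 differs from compound 1 in both the group and its ring position, so 4-carboxyphenyl or 3-carbamoylphenyl on that nitrogen could separate the two changes.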